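A few compounds are considered here, and "the series" means these few. Any claim that something is new, unique, unknown or untested is made for them only; others in the source may bear on it.

Measured compounds in the series:

Compound 1, `Cc1ccc(CN(C)C(=O)c2nn(-c3ccc(F)cc3)c(OC[C@@H](O)C[C@@H](O)CC(=O)O)c2C(C)C)cc1`: in an assay on microsomes from liver for inhibition of 3-hydroxy-3-methylglutaryl-coenzyme A reductase (Rattus norvegicus) (a lower number here means a stronger inhibitor, a higher number a weaker inhibitor), compound 1 gives 37 nM.
Compound 2, `COc1ccccc1CNC(=O)c1nn(-c2ccc(F)cc2)c(OC[C@@H](O)C[C@@H](O)CC(=O)O)c1C(C)C`: in this assay compound 2 gives 22 nM.

Within the data shown here, compound 2 holds the lowest of the two numbers so far; its nearest neighbour is compound 1, and the step of a 1.7-fold lower number from compound 1 to compound 2 (0.23 log units; within the scatter) stays within the scatter, so the two compounds cannot be ordered on these data.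

Compound 3, `CC(C)c1c(C(=O)NCc2ccccc2Cl)nn(-c2ccc(F)cc2)c1OC[C@@H](O)C[C@@H](O)CC(=O)O`, has not yet been measured in this assay. It differs from compound 2 in one place: chloro in place of methoxy on an aromatic carbon. Among the measured compounds shown here, the only measured step exchanges the whole amide substituent, methyl(4-methylbenzyl)amino for (2-methoxybenzyl)amino, and that larger change moved the number no further than the scatter. For the measured compounds named here, no measured step replaces a group on the benzyl ring itself, so the present exchange has no direct precedent here. Going by the values given here, with the one available step within the scatter, a step of similar small size is the working expectation for this assay, in no particular direction.

The value of compound 3 in this assay is therefore estimated at 22 nM, with a range from 8 nM to 60 nM. The expected step is no change at the digits printed from compound 2 to compound 3 (within the scatter).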

Compound 3, half-maximal inhibitory concentration: 9.5 nM
The estimate for compound 3 lay 2.3-fold (0.36 log units) above the measured number; the measured number falls inside the stated range.
By their numbers in this assay, from the lowest: compound 3; then compounds 2 and 1 (each within the scatter of the next).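

In this assay, among these compounds, the exchange of methoxy for chloro is the first change on the benzyl ring itself, and it gives a 2.3-fold lower number from compound 2 to compound 3 (0.36 log units; beyond the scatter). Among the compounds shown here, a single substituent on this aromatic carbon, ortho to a large group, can therefore shift the number by more than the scatter, although the shift is modest, whereas the one earlier step, which replaced the whole amide substituent, stayed within it. Replacing methyl(4-methylbenzyl)amino with (2-chlorobenzyl)amino gives a 3.9-fold lower number from compound 1 to compound 3 (0.59 log units; beyond the scatter), so compound 3 is separated beyond the scatter from both other compounds and holds the lowest number in the series, but no accompanying data bear on the reason for this difference.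

This single exchange does not show whether the lower number is particular to chloro or would also appear with other groups on the same carbon, such as fluoro, bromo, trifluoromethyl or a hydroxyl group. It also leaves open whether chloro on another carbon of the benzyl ring, or a methyl group on the amide nitrogen of the (2-chlorobenzyl)amino group, would keep the number of compound 3.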